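Moving one chloro group: from compound 1 to compound 4

The compounds below may be only part of what the source reports. "The series", "measured", "known", "first", "only" and "open" are said of these compounds alone.

In a functional assay on MCF7 cells (Homo sapiens) for cytotoxicity, with a stated time of 72 h (on this read-out higher numbers stand for weaker inhibition and lower numbers for stronger inhibition), compound 1 `CC(C)[C@H](NC(=O)c1cc(Cl)ccc1O)C(=O)Nc1ccc(Cl)cc1` gives > 10000 nM as a limit and not as a number. Compound 2 `CC(C)[C@H](NC(=O)c1cc(Cl)ccc1O)C(=O)Nc1cccc(Cl)c1` gives > 10000 nM and this is also a limit. Compound 3 `CC(C)[C@H](NC(=O)c1cc(Cl)ccc1O)C(=O)Nc1ccc(C(F)(F)F)cc1` gives 7300 nM as a true number. Compound 4 `CC(C)[C@H](NC(=O)c1ccc(Cl)cc1O)C(=O)Nc1ccc(Cl)cc1` has the same atoms as compound 1, joined differently, with 4-chloro-2-hydroxyphenyl in place of 5-chloro-2-hydroxyphenyl on a carbonyl carbon and nothing else altered. Neither measured step touches this group. The nearest parallel, a moved chloro elsewhere in the molecule, is a step that the two limits leave unreadable from compound 1 to compound 2 and so gives no size to borrow. The other measured change is an at least 1.3-fold lower number from compound 1 to compound 3 (0.13 log units; that floor lies within the scatter) and so shows no firm shift either. No step beyond the scatter is therefore expected in this assay and no direction can be given. The expected step is a step that the limit leaves unreadable from compound 1 to compound 4 and it should be read as an estimate only. For compound 4 the expected half-maximal inhibitory concentration is 11000 nM with an estimated range from 5000 nM to 25000 nM and a limit rather than a number is quite likely.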

Compound 4, half-maximal inhibitory concentration: > 10000 nM
Compound 4: a limit, no number; the forecaster's own chance of this, stated with the estimate: 60%; the middle value is on the limit's open side.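

In this assay compound 4 gives > 10000 nM, which is a limit and not a number. From the compounds shown here alone, compound 1 also gives only a limit, so no step can be read between them, and the values shown share this ceiling: the limit of > 10000 nM in this assay, at which 3 of the 4 values shown sit. Whether 4-chloro-2-hydroxyphenyl in place of 5-chloro-2-hydroxyphenyl changes the read-out at all stays open.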